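The source may hold more compounds than are shown below. What is called first, only, known or untested is meant among the compounds shown, and "the series" means these compounds.

Compounds measured in a functional assay on MCF7 cells (Homo sapiens) for cytotoxicity, read by MTT assay, with a stated time of 72 h; a lower number here means a stronger inhibitor, a higher number a weaker inhibitor:
- compound 1 `Nc1cc2nc(-c3ccccc3)nn(-c3ccccc3)c-2cc1=O` gives 950 nM
- compound 2 `CNc1cc2nc(-c3ccccc3)nn(-c3ccccc3)c-2cc1=O` gives 690 nM
- compound 3 `CCN(CC)c1cc2nc(-c3ccccc3)nn(-c3ccccc3)c-2cc1=O` gives > 5000 nM

The entry for compound 3 is a limit and not a number: it stands at the limit of > 5000 nM in this assay, at which 1 of the 3 values shown sits. Compound 4 `O=c1cc2n(-c3ccccc3)nc(-c3ccccc3)nc-2cc1N1CCCC1` carries pyrrolidin-1-yl in place of diethylamino on an aromatic carbon, a change counted as pyrrolidin-1-yl in place of diethylamino on an aromatic carbon. Among the compounds with values here, no measured step makes this exact exchange. The nearest evidence is an at least 5.2-fold higher number from compound 1 to compound 3 (0.72 log units; beyond the scatter), together with an at least 7.2-fold higher number from compound 2 to compound 3 (0.86 log units; beyond the scatter). Both steps end at the limit, so they give only a minimum size, and neither involves a ring. By contrast, a 1.4-fold lower number from compound 1 to compound 2 (0.14 log units; within the scatter). Within the data shown here, since compound 4 replaces the diethylamino group of compound 3 with a group of matching heavy-atom count, it is expected to stay close to compound 3 in this assay, with no firm direction and no large step. The expected step is an at least 1.2-fold lower number from compound 3 to compound 4 (0.09 log units; that floor lies within the scatter). For compound 4 the estimated value is 4000 nM, with an expected range from 1200 nM to 12000 nM.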

Compound 4, half-maximal inhibitory concentration: 360 nM
The estimate for compound 4 lay 11-fold (1.05 log units) above the measured number; the measured number lies below the stated range.
By their numbers in this assay, from the lowest: compounds 4, 2 and 1 (each within the scatter of the next, the first and the last beyond it). At a limit, above all of these: compound 3.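

In this assay, closing the diethylamino group into pyrrolidin-1-yl on this aromatic carbon gives an at least 13-fold lower number from compound 3 to compound 4 (1.14 log units; beyond the scatter) with the heavy-atom, donor and acceptor counts unchanged, so those counts do not separate the two groups. Set against the smaller groups, the pyrrolidin-1-yl compound shows a 1.9-fold lower number from compound 2 to compound 4 (0.28 log units; within the scatter) and a 2.6-fold lower number from compound 1 to compound 4 (0.42 log units; beyond the scatter) at this position, so a group of this size can be carried here without the loss seen for compound 3. Compound 3 has a limit and not a number, which makes the first step a minimum: the limit of > 5000 nM in this assay, at which 1 of the 4 values shown sits.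

How far this tolerance extends to other rings remains open, as piperidin-1-yl, morpholin-4-yl and azetidin-1-yl stand outside the compounds shown. Open-chain amines such as dimethylamino would show whether the ring itself matters or only the length of the chains.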